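A few compounds are considered here, and "the series" means these few. Any claim that something is new, unique, unknown or untested is made for them only; others in the source may bear on it.

The measured compounds, each with its number in an assay on CHO cells for displacement of a labelled ligand from adenosine receptor A1 (Homo sapiens), read by scintillation counting, with a stated time of 1 h, tested at 1 uM; a lower number here means less inhibition, a higher number more inhibition at the concentration tested (going by the name of the read-out):

compound 1, `Nc1ncc(-c2ccccc2)c(-c2ccccc2)n1`, 32%
compound 2, `Nc1ncc(-c2ccncc2)c(-c2ccccc2)n1`, > 80%
compound 3, `O=C(Nc1ncc(-c2cccc(Cl)c2)c(-c2ccccc2)n1)C1CCC1`, 52%

The value of compound 2 is a limit of this assay, not a number; it sits at the limit of > 80% in this assay, at which 1 of the 3 values shown sits. Among the two numbers shown, compound 3 stands highest, and its nearest neighbour is compound 1, whose number is lower by a gap beyond the scatter. Going by the values given here, the one measured step, a number at least 48 percentage points higher from compound 1 to compound 2 (beyond the scatter), concerns a change on an aromatic carbon and is large.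

Compound 4, `Clc1cccc(-c2cnc(NCc3ccccc3)nc2-c2ccccc2)c1`, differs from compound 3 in benzyl in place of cyclobutylcarbonyl on a nitrogen on an aromatic ring. Among the compounds with values here, no measured step touches this nitrogen, so the step from compound 1 to compound 2 gives no guide to its size or direction. Compound 4 is therefore expected to sit near compound 3, with the step of a number 2 percentage points lower from compound 3 to compound 4 (within the scatter) anticipated to stay within the scatter. The estimate for compound 4 in this assay is 50%, between 25% and 78%.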

Compound 4, a percentage reported as inhibition, at one concentration (the size of the read-out at that concentration, not a potency): 16%
Compound 4: middle estimate off by 34 percentage points, on the high side; the whole stated range lies above it.
By their numbers in this assay, from the lowest: compound 4; then compound 1; then compound 3. At a limit, above all of these: compound 2.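

In this assay, the nitrogen on an aromatic ring turns out to be sensitive to what it carries: a number 36 percentage points lower from compound 3 to compound 4 (beyond the scatter) and the step is large. Going by these compounds alone, this is the first measured change at this nitrogen, and it shows that benzyl cannot stand in for cyclobutylcarbonyl here without a clear loss of inhibition. Nothing measured among these compounds accounts for the size of this step.

The compounds shown leave open whether the lower number follows from the loss of the carbonyl or from the arrival of the benzyl ring. They also leave open how an acetyl group, a longer alkyl chain or a carboxylic acid on this nitrogen would read, with the rest of compound 3 unchanged.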